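Trimming the pentyl chain on the core of compound 1

This account rests on a few compounds, and the source may have more. Where it says the series, first, only, none or still open, it means among the compounds named here.

Compound 1, with structure `CCCCCc1cc(-c2cn([C@H]3C[C@H](OC(C)=O)[C@@H](COC(C)=O)O3)c(=O)[nH]c2=O)on1`, carries a 3-pentyl-1,2-oxazol-5-yl group on its shared core. In a functional assay on NCI-H23 cells (Homo sapiens) for cytotoxicity, read by sulforhodamine B assay, tested at 10 uM (on this read-out higher numbers stand for more inhibition at the one concentration tested (going by the name of the read-out) and lower numbers for less inhibition), compound 1 gives 88.9%. Two related compounds were run alongside it. Compound 2, `CC(=O)OC[C@H]1O[C@@H](n2cc(-c3cn(Cc4ccc(C(C)C)cc4)nn3)c(=O)[nH]c2=O)C[C@@H]1OC(C)=O`, gives 86.7% in this assay, and compound 3, `CC(C)(C)c1ccc(-c2cc(-c3cn([C@H]4C[C@H](O)[C@@H](CO)O4)c(=O)[nH]c3=O)on2)cc1`, gives 98.9%. The number for compound 1 differs from that of compound 2 and from that of compound 3 by amounts that stay within the usual scatter of repeated measurements, so the three cannot be ranked against one another on these data.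

The unmeasured compound 4, `CC(=O)OC[C@H]1O[C@@H](n2cc(-c3cc(C)no3)c(=O)[nH]c2=O)C[C@@H]1OC(C)=O`, keeps the core and both acetyl groups of compound 1 and changes one place only:

hydrogen in place of butyl on a saturated chain carbon bound to an aromatic carbon

Going by the values given here, no pair of measured compounds shows this particular change, so no measured step guides the expectation. With hydrogen in place of butyl on a saturated chain carbon bound to an aromatic carbon, compound 4 is expected to fall short of compound 1 in this assay, by a step estimated as a number 28.9 percentage points lower from compound 1 to compound 4 (beyond the scatter), a loss beyond the scatter. On that basis compound 4 is estimated to give 60% in this assay, with a range from 25% to 90%.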

Compound 4, a percentage reported as inhibition, at one concentration (the size of the read-out at that concentration, not a potency): 101%
Estimate against measurement, compound 4: 41 percentage points below; measured number outside the range, above it.
By their numbers in this assay, from the lowest: compounds 2, 1, 3 and 4 (each within the scatter of the next, the first and the last beyond it).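

In this assay, hydrogen in place of butyl on a saturated chain carbon bound to an aromatic carbon gives a number 12.1 percentage points higher from compound 1 to compound 4 (beyond the scatter), which turns the 3-pentyl-1,2-oxazol-5-yl group into 3-methyl-1,2-oxazol-5-yl. Going by these compounds alone, this is the first measured change at this place, and it shows that, with both acetyl groups kept on the shared core, the butyl part of the chain is not required for the read-out, since removing it brings a modest gain rather than a loss. Nothing available explains why the shorter group reads higher.

The compounds shown leave open how the read-out runs through intermediate lengths such as an ethyl or propyl chain, and what a longer chain, an amine or a carboxylic acid would give on that saturated chain carbon. They also leave open whether the same change would give a similar step on a core with free hydroxyl groups in place of the acetyl groups, and whether this step at one concentration would carry over to a measure of potency.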